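The source may hold more compounds than are shown below. What is called first, only, known or untested is meant among the compounds shown, and "the series" means these compounds.

Going by the values given here, the three compounds measured so far share one core, differing only in the groups hung on it. Among the compounds with values here, compound 1 `[O-]/[N+](=C\c1cn(-c2ccc(Cl)cc2)nn1)c1ccccc1` is the only one to give a number: in a functional assay on PC-3 cells (Homo sapiens) for inhibition, read by MTT assay, with a stated time of 24 h (a lower number here means a stronger inhibitor, a higher number a weaker inhibitor), compound 1 gives 11100 nM. Compound 2 `CCCCCCCCCCn1cc(/C=[N+](\[O-])c2ccccc2)nn1` is a different case. In this assay compound 2 gives only a limit, > 100000 nM. Compound 3 `[O-]/[N+](=C\c1cn(-c2ccc(C(F)(F)F)cc2)nn1)Cc1ccccc1` likewise gives only a limit in this assay, > 100000 nM. So compound 2 stands at the weak end of what has been measured, together with compound 3, both sitting at the limit of > 100000 nM in this assay, at which 2 of the 3 values shown sit, while compound 1 alone lies inside the measurable range.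

Compound 4 `CCCCCCCCCCn1cc(/C=[N+](\[O-])Cc2ccccc2)nn1` has not yet been measured. It differs from compound 2 by benzyl in place of phenyl on a double-bonded nitrogen. Within the data shown here, no measured pair shows this exchange on its own, and compound 3, which already carries the benzyl group, also gives no number. The account therefore expects no step beyond the scatter in either direction, with a fair chance that only a limit is reported again; the step expected here is a step that the limit leaves unreadable from compound 2 to compound 4. Compound 4 is estimated at 150000 nM, with a range from 50000 nM to 500000 nM.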

Compound 4, half-maximal inhibitory concentration: > 100000 nM
Compound 4 ended at the assay's limit (the forecaster's own chance of this, stated with the estimate: 75%); the middle value is on the limit's open side.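

In this assay compound 4 gives only a limit, > 100000 nM. Compound 2 also gives only a limit, so no step can be read between compound 2 and compound 4: the limit of > 100000 nM in this assay, at which 3 of the 4 values shown sit. The compounds shown leave open whether benzyl in place of phenyl on a double-bonded nitrogen changes inhibition at all.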